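The source may report more compounds than this note shows. Statements on the series, on what has been measured and on what is new or still open speak of the compounds shown alone.

Measured compounds:
- compound 1 `COC(=O)c1ccc(-c2noc(CCl)n2)cc1`, in an ADME assay on MT2 cells (Homo sapiens) for cytotoxicity, read by XTT assay, with a stated time of 4 days (on this read-out lower numbers stand for higher toxicity in this test and higher numbers for lower toxicity in this test), compound 1 gives 14200 nM
- compound 2 `O=C(O)c1ccc(-c2noc(CBr)n2)cc1`, in this assay compound 2 gives 81900 nM

Of the compounds shown here, two share a core and have been tested, and only one number each is known. On the numbers shown, compound 2 stands as the higher of the two, with compound 1 giving the lower figure; the gap between them lies beyond the usual scatter, so compound 2 is the less toxic of the pair in this assay. Among the compounds with values here, compound 1 and compound 2 differ in more than one place, so no single step between them is traced here.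

The step now followed leads from compound 2 to compound 3 `O=C(O)c1ccc(-c2noc(CO)n2)cc1`, which has not been measured yet. The change is hydroxy in place of bromo on a saturated chain carbon bound to an aromatic carbon. Within the data shown here, with no comparable step among the measured compounds, the size of this change in this assay rests only on the two values shown. The expectation is a step upward, toward a higher number, and probably beyond the scatter, as a 2.0-fold higher number from compound 2 to compound 3 (0.29 log units; within the scatter). For compound 3 the estimated value in this assay is 160000 nM, with a range from 50000 nM to 450000 nM.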

Compound 3, half-maximal cytotoxic concentration: 455000 nM
Beside the measured number, compound 3's estimate is 2.8-fold (0.45 log units) below it; measured number above the stated range.
By their numbers in this assay, from the lowest: compound 1; then compound 2; then compound 3.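

Within the data shown here, this is the first single change that can be read at this position: in this assay, hydroxy in place of bromo on a saturated chain carbon bound to an aromatic carbon gives a 5.6-fold higher number from compound 2 to compound 3 (0.74 log units; beyond the scatter), and a higher number here stands for lower toxicity in this test. The position is therefore not indifferent, since the group on this chain carbon moves the read-out clearly while the rest of the molecule stays the same, something the first pair could not show because compound 1 and compound 2 differ in more than one place. No other measurement bears on this step, and the data offer no explanation for it.

One step cannot tell whether the rise comes from bromo leaving or from hydroxy entering, and a methyl, a methoxy or an amine on the same carbon would help to separate the two. From the compounds shown here alone, it also remains open whether the same change would give a similar step on another background, such as the methyl ester of compound 1.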